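The compounds below may be only part of what the source reports. "The series", "measured", "known", "first", "only" and "open" are said of these compounds alone.

Measured compounds:
compound 1 `ClCc1cccc(Cn2cnc3c(Cl)ncnc32)c1` — 81300 nM
compound 2 `ClCc1ccccc1Cn1cnc2ncnc(Cl)c21` — 66100 nM
compound 3 `ClCc1cccc(Cn2cnc3nc(Cl)nc(Cl)c32)c1` — "not determined" (no result reported)

In a functional assay on Hs-578T cells (Homo sapiens) for cytotoxicity, read by sulforhodamine B assay, with a stated time of 48 h (on this read-out higher numbers stand for lower toxicity in this test and lower numbers for higher toxicity in this test), compound 2 gives 66100 nM, and compound 1 gives 81300 nM; the gap between these two lies within the scatter of repeated measurements, so compound 2 does not stand apart from compound 1 on the numbers shown. In this assay compound 3 has no number; its entry reads "not determined" (no result reported).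

Compound 4 `ClCc1ccccc1Cn1cnc2nc(Cl)nc(Cl)c21` differs from compound 2 by chloro in place of hydrogen on an aromatic carbon. Going by the values given here, no measured pair shows this single change, so nothing in the data fixes its size; a step of modest size is expected, if anything toward lower numbers, and possibly not beyond the scatter. For compound 4 the estimated result in this assay is 50000 nM, within 15000 nM to 150000 nM, which is expected to mean a 1.3-fold lower number from compound 2 to compound 4 (0.12 log units; within the scatter).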

Compound 4, concentration lethal to 50% of the cells: > 100000 nM
Compound 4: a limit, no number (the forecaster's own chance of this, stated with the estimate: 20%); middle value at least 2.0-fold (0.30 log units) from the limit.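

Compound 4 gives only a limit in this assay, > 100000 nM, and not a number. Going by these compounds alone, this is the first single-place change that can be read here: chloro in place of hydrogen on an aromatic carbon, between two ring nitrogen atoms, gives an at least 1.5-fold higher number from compound 2 to compound 4 (0.17 log units; that floor lies within the scatter). The full size of the step stays unread because the result is a limit: the limit of > 100000 nM in this assay, at which 1 of the 4 values shown sits.

Compound 3 has no number, so the same change cannot be read from compound 1. On these data alone, whether an amine or a methoxy group at this position would give a different result remains open.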